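Sulfonamide aryl changes in the compound 1 series

This account rests on a few compounds, and the source may have more. Where it says the series, first, only, none or still open, it means among the compounds named here.

Values in a functional assay on M21 cells (Homo sapiens) for antiproliferative activity, read by sulforhodamine B assay, with a stated time of 48 h (a lower number here means a stronger inhibitor, a higher number a weaker inhibitor), so far:
- compound 1 (`O=C1NCCN1c1ccc(S(=O)(=O)Nc2ccc(F)cc2)cc1`) 230 nM
- compound 2 (`O=C1NCCN1c1ccc(S(=O)(=O)Nc2cccc(Br)c2)cc1`) 59 nM
- compound 3 (`Cc1cc(C)cc(NS(=O)(=O)c2ccc(N3CCNC3=O)cc2)c1`) 63 nM

Compound 1 stands highest of the three, as the weakest inhibitor here. Compound 4 (`O=C1NCCN1c1ccc(S(=O)(=O)Nc2ccc(OC(F)F)cc2)cc1`) has difluoromethoxy in place of fluoro on an aromatic carbon, para to a large group (difluoromethoxy in place of fluoro on an aromatic carbon). Two measured steps replace the same 4-fluorophenyl group (a 3.9-fold lower number from compound 1 to compound 2 (0.59 log units; beyond the scatter) and a 3.7-fold lower number from compound 1 to compound 3 (0.56 log units; beyond the scatter)), and both are modest. Neither introduces difluoromethoxy, so they guide only loosely. A modest step to a lower number is therefore expected in this assay, no larger than those two. The expected change is a 2.3-fold lower number from compound 1 to compound 4 (0.36 log units; beyond the scatter) in this estimate. For compound 4 the estimated value is 100 nM (expected range 35 nM to 280 nM).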

Compound 4, half-maximal inhibitory concentration: 410 nM
Compound 4: the middle estimate sits 4.1-fold (0.61 log units) below what was measured; measured number above the stated range.
By their numbers in this assay, from the lowest: compounds 2 and 3 (each within the scatter of the next); then compounds 1 and 4 (each within the scatter of the next).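

In this assay, difluoromethoxy in place of fluoro on the aromatic carbon para to a large group gives a 1.8-fold higher number from compound 1 to compound 4 (0.25 log units; within the scatter) and leaves compound 4 unseparated from compound 1, so the larger group at this position brings no gain. Compound 2 and compound 3, the two with lower numbers, carry no group at that position. Nothing available here accounts for this result.

From the compounds shown here alone, it remains open whether a methoxy group or an amine at this position would read like fluoro and difluoromethoxy. Whether a difluoromethoxy group elsewhere on the ring would match compound 2 is also unresolved.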